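Swapping a phenyl for an anilino group at the carbonyl

The source may hold more compounds than are shown below. What is called first, only, known or untested is meant among the compounds shown, and "the series" means these compounds.

Compound 1 `O=C(Nc1cccc(-n2cc(-c3ccncc3)c(-c3ccc(Cl)c(O)c3)n2)c1)Nc1cccc(C(F)(F)F)c1`: > 32500 nM (a limit)
Compound 2 `COc1cc(-c2nn(-c3cccc(NC(=O)c4cccc(C(F)(F)F)c4)c3)cc2-c2ccncc2)ccc1Cl`: > 50000 nM (a limit)

Both entries come from a functional assay on HT-29 cells (Homo sapiens) for inhibition, read by sulforhodamine B assay, with a stated time of 48 h; on this read-out lower numbers stand for higher toxicity in this test and higher numbers for lower toxicity in this test. Compound 2 stands at > 50000 nM, and this is a limit rather than a number. Compound 1 also has only a limit, > 32500 nM. The two compounds therefore cannot be placed in order, and neither can serve as an exact reference point.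

Compound 3 `COc1cc(-c2nn(-c3cccc(NC(=O)Nc4cccc(C(F)(F)F)c4)c3)cc2-c2ccncc2)ccc1Cl` differs from compound 2 in one place. On a carbonyl carbon, (3-(trifluoromethyl)phenyl)amino stands in place of 3-(trifluoromethyl)phenyl ((3-(trifluoromethyl)phenyl)amino in place of 3-(trifluoromethyl)phenyl on a carbonyl carbon). Among the compounds with values here, no measured pair shows this exchange on its own, so any forecast has thin support. Compound 1 already carries the entering group on its carbonyl carbon, yet its result in this assay is the limit > 32500 nM. On that basis, no change beyond the scatter is expected, and another limit is the likeliest report. The estimated step of an at least 1.1-fold lower number from compound 2 to compound 3 (0.07 log units; that floor lies within the scatter) is expected to be small, with no firm direction. For compound 3, the expected value is 42000 nM, with an estimated range of 15000 nM to 100000 nM.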

Compound 3, concentration lethal to 50% of the cells: 4670 nM
Compound 3: the middle estimate sits 9.0-fold (0.95 log units) above what was measured; measured number outside the range, below it.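

In this assay, the group on this carbonyl carbon clearly matters: putting (3-(trifluoromethyl)phenyl)amino in place of 3-(trifluoromethyl)phenyl gives an at least 10-fold lower number from compound 2 to compound 3 (1.02 log units; beyond the scatter), which means higher toxicity in this test. The entering group does not decide the result alone, since compound 1 carries it too, and methyl in place of hydrogen on an oxygen on an aromatic ring gives an at least 6.9-fold lower number from compound 1 to compound 3 (0.84 log units; beyond the scatter). Neither step has an exact size, because each starts from a compound reported only as a limit, and for compound 2 the record is this: the limit of > 50000 nM in this assay, at which 1 of the 3 values shown sits.

On these data alone, it remains open whether the nitrogen of the entering group is what counts, or whether a methylene or an oxygen at the same place on the carbonyl carbon would give a similar number. It is also unknown whether a longer chain such as ethyl on that aromatic oxygen would keep the lower number, or whether a free amine on the same ring would change the result.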